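Swapping Nitro for Amino on a Shared Core

The source may report more compounds than this note shows. Statements on the series, on what has been measured and on what is new or still open speak of the compounds shown alone.

Compound 1 `O=c1ccn(COC(CO)CO)c(=O)[nH]1`: > 462000 nM
Compound 2 `O=c1[nH]c(=O)n(COC(CO)CO)cc1[N+](=O)[O-]`: > 383000 nM

Of the compounds shown here, two have so far been tested in a functional assay on HepG2 cells (Homo sapiens) for cytotoxicity; on this read-out lower numbers stand for higher toxicity in this test and higher numbers for lower toxicity in this test. For compound 1 the value > 462000 nM is a limit of the test, not a measured number. For compound 2 the value > 383000 nM is likewise a limit. Compound 2 carries a nitro group on an aromatic carbon where compound 1 carries hydrogen, and the step that the two limits leave unreadable from compound 1 to compound 2 cannot be read as a size, since both of its ends are limits: the limit of > 383000 nM in this assay, at which 1 of the 2 values shown sits, and (the limit of > 462000 nM in this assay, at which 1 of the 2 values shown sits).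

Compound 3 `Nc1cn(COC(CO)CO)c(=O)[nH]c1=O` carries an amino group in place of the nitro group of compound 2: amino in place of nitro on an aromatic carbon. Among the measured compounds shown here, only the one step from compound 1 to compound 2 bears on a change at this aromatic carbon, and it shows no readable size. There is thus no ground to expect a step in this assay beyond the usual scatter in either direction, and compound 3 is expected to show no measurable toxicity either. The expected step is a step that the limit leaves unreadable from compound 2 to compound 3. For compound 3 the estimate is 400000 nM with a range from 150000 nM to 1000000 nM.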

Compound 3, half-maximal cytotoxic concentration: > 432000 nM
Compound 3 gave a limit, no number; the forecaster's own chance of this, stated with the estimate: 85%; middle value at least 1.0-fold (0.03 log units) away from the limit.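

In this assay compound 3 gives > 432000 nM, which is a limit and not a number. Among the compounds shown here, no step among compound 1, compound 2 and compound 3 can be read, as all three values are limits. The compounds shown leave open whether any group at this aromatic carbon changes the result in this assay, and by how much.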